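Methoxy for methyl on the trifluoromethyl-bearing ring

The compounds below may be only part of what the source reports. "The series", "measured", "known", "first", "only" and "open" are said of these compounds alone.

Compound 1 `Cc1ccc(-n2cc(-c3ccc(CN4CCN(C)CC4)c(C(F)(F)F)c3)nn2)cc1Nc1nccc(-c2cccnc2)n1`: 40 nM in a functional assay on K562 cells (Homo sapiens) for inhibition, read by MTT assay, with a stated time of 72 h; on this read-out higher numbers stand for weaker inhibition and lower numbers for stronger inhibition
Compound 2 `Cc1ccc(-n2cc(-c3ccc(C)c(C(F)(F)F)c3)nn2)cc1Nc1nccc(-c2cccnc2)n1`: > 30000 nM in this assay

Compound 2 stands only at a limit of this assay, > 30000 nM, with no number below it. Compound 1 sits at the other end, with an at least 750-fold higher number from compound 1 to compound 2 (2.87 log units; beyond the scatter). Compound 3 `COc1ccc(-c2cn(-c3ccc(C)c(Nc4nccc(-c5cccnc5)n4)c3)nn2)cc1C(F)(F)F` differs from compound 2 by methoxy in place of methyl on an aromatic carbon. For the measured compounds named here, no measured step touches this group; the one step known concerns a different position and removes a basic amine, so it gives no guide here. Compound 3 is therefore expected to remain near the limit, a number no higher from compound 2 to compound 3 (the limit leaves the size open), with an estimate of 30000 nM within 10000 nM to 100000 nM.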

Compound 3, half-maximal inhibitory concentration: 11200 nM
Estimate against measurement, compound 3: 2.7-fold (0.43 log units) above; low and high end bracket the measured number.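

Compound 2 is held only at a limit: the limit of > 30000 nM in this assay, at which 1 of the 3 values shown sits.

Methoxy in place of methyl on this carbon, ortho to a trifluoromethyl group, gives a measurable number in this assay, with an at least 2.6-fold lower number from compound 2 to compound 3 (0.42 log units; beyond the scatter), so the position responds to a small change, though the true size of the step stays unknown. Set against (4-methylpiperazin-1-yl)methyl on the same carbon, methoxy still falls far short, with a 280-fold higher number from compound 1 to compound 3 (2.45 log units; beyond the scatter).

From the compounds shown here alone, whether ethoxy or hydroxyl would follow methoxy here remains open. So does whether a simpler amine, such as aminomethyl, would come closer to compound 1.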